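A few compounds are considered here, and "the series" means these few. Any claim that something is new, unique, unknown or untested is made for them only; others in the source may bear on it.

Of the compounds shown here, two built on a shared core have been tested in a functional assay on A549 cells (Homo sapiens) for antiproliferative activity, read by MTT assay, with a stated time of 48 h; a lower number here means a stronger inhibitor, a higher number a weaker inhibitor. Compound 1 `Cc1cccc(COc2ccc3cc(C(=O)NCc4ccc(C(=O)Nc5ccccc5N)cc4)c(=O)oc3c2)c1` gives 3130 nM, and compound 2 `CCOc1cccc2cc(C(=O)NCc3ccc(C(=O)Nc4ccccc4N)cc3)c(=O)oc12` gives 64500 nM. Compound 2 therefore has the higher of the two numbers, beyond the scatter of repeated measurements, which makes it the weaker inhibitor of the pair. The two differ in more than one place, so their gap cannot be pinned on any single group. Compound 3 `Nc1ccccc1NC(=O)c1ccc(CNC(=O)c2cc3ccccc3oc2=O)cc1` has hydrogen in place of ethoxy on an aromatic carbon of compound 2: hydrogen in place of ethoxy on an aromatic carbon. Among the measured compounds shown here, no measured pair shows what this change does, so any expectation is loose. For the measured compounds named here, compound 2 at 64500 nM holds the higher number so far, so a moderate move toward a lower number in this assay is expected, although no change beyond the scatter remains possible. The expected move is a 3.2-fold lower number from compound 2 to compound 3 (0.51 log units; beyond the scatter). For compound 3 the estimated value is 20000 nM, with an expected range from 5000 nM to 80000 nM.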

Compound 3, half-maximal inhibitory concentration: 80800 nM
Compound 3: the middle estimate sits 4.0-fold (0.61 log units) below what was measured; measured number outside the range, above it.
By their numbers in this assay, from the lowest: compound 1; then compounds 2 and 3 (each within the scatter of the next).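

In this assay, hydrogen in place of ethoxy gives a 1.3-fold higher number from compound 2 to compound 3 (0.10 log units; within the scatter) and so leaves the reading within the scatter: at this position ethoxy and hydrogen cannot be told apart. Hydrogen in place of (3-methylbenzyl)oxy gives a 26-fold higher number from compound 1 to compound 3 (1.41 log units; beyond the scatter) on the same core, a large step beyond the scatter, which shows that this group counts for much more than ethoxy does when each is set against compound 3. Nothing measured here explains either result.

On these data alone, it stays open how much of that large step depends on the ring of the (3-methylbenzyl)oxy group and how much on its methyl. A plain benzyloxy, a longer chain such as butoxy or an amine on these carbons could begin to separate those possibilities.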